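This account rests on a few compounds, and the source may have more. Where it says the series, first, only, none or still open, it means among the compounds named here.

Compounds measured so far:
compound 1, `CC(C(=O)NCc1ccc(C(C)(C)C)cc1N1CCCC1)c1ccc(NS(C)(=O)=O)c(F)c1`, 8.1 nM
compound 2, `CCCCCCOc1cc(C(C)(C)C)ccc1CNC(=O)C(C)c1ccc(NS(C)(=O)=O)c(F)c1`, 0.5 nM

Going by the values given here, in an assay on cells for antagonist activity at transient receptor potential cation channel subfamily V member 1 (Homo sapiens), read by FLIPR and calcium flux, with a stated time of 6 min (a higher number here means a weaker inhibitor, a lower number a stronger inhibitor), compound 2 gives the lowest of the two numbers; the only neighbour is compound 1, and the step of a 16-fold lower number from compound 1 to compound 2 (1.21 log units; beyond the scatter) separates them, a large one, beyond the scatter. Compound 3, `CCCCCc1cc(C(C)(C)C)ccc1CNC(=O)C(C)c1ccc(NS(C)(=O)=O)c(F)c1`, differs from compound 2 by pentyl in place of hexyloxy on an aromatic carbon. Among the compounds with values here, the one measured step concerns the same position of the core but a different exchange, hexyloxy in place of pyrrolidin-1-yl, so it bears on the present change only as a sign that this position responds strongly to what sits on it. Within the data shown here, no measured pair shows what happens when the oxygen link is dropped and the chain shortened while an alkyl group remains. With both compound 2 and compound 1 as the frame, the expectation for compound 3 in this assay is a step of a 3.0-fold higher number from compound 2 to compound 3 (0.48 log units; beyond the scatter), most likely a moderately higher number than that of compound 2 but well inside the range marked out by compound 1. The estimate for compound 3 is 1.5 nM, with a range from 0.4 nM to 6 nM.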

Compound 3, inhibition constant: 2.8 nM
Estimate against measurement, compound 3: 1.9-fold (0.27 log units) below, within the range that was stated.
By their numbers in this assay, from the lowest: compound 2; then compound 3; then compound 1.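

Working notes on the series: in this assay the exchange of hexyloxy for pentyl gives a 5.6-fold higher number from compound 2 to compound 3 (0.75 log units; beyond the scatter), so this position separates two open chains and not only a chain from the ring of pyrrolidin-1-yl. Pentyl still keeps part of the gain over pyrrolidin-1-yl, with a 2.9-fold lower number from compound 1 to compound 3 (0.46 log units; beyond the scatter), and the three compounds now fall in the order compound 2, compound 3, compound 1, with compound 2 the strongest inhibitor and every printed step beyond the usual scatter. No measurement on hand accounts for this order among the three groups.

The exchange from hexyloxy to pentyl removes the oxygen link and changes the chain at once, so its two parts stay unseparated; hexyl or pentyloxy on the same aromatic carbon would divide the step between them. Also open, from the compounds shown here alone, is how far the trend extends on this carbon, for instance with a longer chain such as octyloxy, a shorter one such as ethoxy, or an open-chain amine such as diethylamino in place of the ring of pyrrolidin-1-yl.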